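A Trifluoromethyl Group Replaces a Nitro Group

A few compounds are considered here, and "the series" means these few. Any claim that something is new, unique, unknown or untested is made for them only; others in the source may bear on it.

Compound 1 `CN(C(=O)NC(=O)c1cccc([N+](=O)[O-])c1)c1nc(C(F)(F)F)c(C(=O)N/N=C/c2ccccc2C(F)(F)F)s1` carries an acyl urea at one end of the shared core and a hydrazone at the other. In a functional assay on MCF7 cells (Homo sapiens) for inhibition, read by MTT assay, with a stated time of 72 h (a higher number here means a weaker inhibitor, a lower number a stronger inhibitor), compound 1 gives 4.73 ug/mL. Compound 2 `CN(C(=O)NC(=O)c1ccc(Cl)c(Cl)c1)c1nc(C(F)(F)F)c(C(=O)N/N=C/c2cccc([N+](=O)[O-])c2)s1` differs at both ends, and in this assay compound 2 gives 7.51 ug/mL. Of the two numbers, compound 1 gives the smaller, yet the gap to compound 2 lies within the scatter, so neither can be called the stronger. Compound 3 `CNc1nc(C(F)(F)F)c(C(=O)N/N=C/c2ccccc2C(F)(F)F)s1` lacks the acyl urea, and in this assay compound 3 reaches only > 100 ug/mL, which is a limit of the assay and not a number. That is the limit of > 100 ug/mL in this assay, at which 1 of the 3 values shown sits.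

Compound 4 `CN(C(=O)NC(=O)c1ccc(C(F)(F)F)cc1)c1nc(C(F)(F)F)c(C(=O)N/N=C/c2ccccc2C(F)(F)F)s1` has not yet been measured. It is built from compound 1 by one change: 4-(trifluoromethyl)phenyl in place of 3-nitrophenyl on a carbonyl carbon. For the measured compounds named here, no pair of measured compounds shows this change alone, so its effect is unknown. The step of a 1.3-fold higher number from compound 1 to compound 4 (0.10 log units; within the scatter) is expected to stay within the scatter, in either direction. Compound 4 is therefore estimated at 6 ug/mL, within 2.5 ug/mL to 15 ug/mL.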

Compound 4, half-maximal inhibitory concentration: 2.21 ug/mL
The estimate for compound 4 lay 2.7-fold (0.43 log units) above the measured number; the whole stated range lies above it.
By their numbers in this assay, from the lowest: compound 4; then compounds 1 and 2 (each within the scatter of the next). At a limit, above all of these: compound 3.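

This position responds to change. At the carbonyl carbon of the acyl urea, in this assay, putting 4-(trifluoromethyl)phenyl in place of 3-nitrophenyl gives a 2.1-fold lower number from compound 1 to compound 4 (0.33 log units; beyond the scatter) and so gives a modest step that lies beyond the scatter. The earlier compounds shown here could not show this, as none of them formed a pair differing at this one place, and compound 4 now shows that a number this low does not depend on a nitro group. No measurement shown bears on why the number drops with this change.

One step with one replacement group cannot show how far the number can go at this position. As far as these compounds go, what a plain phenyl, an aminophenyl or a carboxyphenyl would give on the same carbonyl carbon remains open.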